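Removing One Fluoro Group: Expected Effect on Growth Inhibition

This account rests on a few compounds, and the source may have more. Where it says the series, first, only, none or still open, it means among the compounds named here.

Measured in a functional assay on HTB-54 cells (Homo sapiens) for cytotoxicity, read by MTT assay, with a stated time of 72 h; on this read-out higher numbers stand for weaker inhibition of growth and lower numbers for stronger inhibition of growth:
Compound 1 `CCCCOC(=O)Nc1ccc([Se]C#N)cc1`: 17200 nM
Compound 2 `CC(C)COC(=O)Nc1ccc([Se]C#N)cc1`: 27100 nM
Compound 3 `N#C[Se]c1ccc(NC(=O)Oc2ccc(F)cc2)cc1`: 25000 nM

Compound 3 stands second highest of the three numbers. Its nearest neighbour is compound 2, and its furthest is compound 1, yet both of those gaps fall within the usual scatter of this assay, so the three measured compounds cannot be told apart on these numbers.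

Compound 4 `N#C[Se]c1ccc(NC(=O)Oc2ccccc2)cc1` is not yet measured. It differs from compound 3 in one place: hydrogen in place of fluoro on an aromatic carbon. Among the measured compounds shown here, the only measured step that can be compared is a 1.6-fold higher number from compound 1 to compound 2 (0.20 log units; within the scatter), and that step changed the saturated chain on the ester oxygen rather than anything on an aromatic ring. For the measured compounds named here, no measured pair shows what a fluoro-to-hydrogen swap on the ring does, and the one step available stayed within the scatter. With no evidence pointing in either direction, the expectation for compound 4 is a step of about no change at the digits printed from compound 3 to compound 4 (within the scatter), not beyond the scatter. Compound 4 is therefore estimated to give 25000 nM in this assay, with a likely range from 11000 nM to 60000 nM.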

Compound 4, concentration for 50% growth inhibition: 26200 nM
Compound 4: middle estimate off by 1.0-fold (0.02 log units), on the low side, and the stated range covers the measured number.
By their numbers in this assay, from the lowest: compounds 1, 3, 4 and 2 (each within the scatter of the next).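

In this assay, the first change made on the aromatic ring itself, hydrogen in place of fluoro para to a large group, gives a 1.0-fold higher number from compound 3 to compound 4 (0.02 log units; within the scatter), so losing this fluoro leaves no visible mark on growth inhibition in these cells. The result also allows a new comparison at the oxygen next to the carbonyl group: phenyl in place of isobutyl gives a 1.0-fold lower number from compound 2 to compound 4 (0.01 log units; within the scatter), and phenyl in place of butyl gives a 1.5-fold higher number from compound 1 to compound 4 (0.18 log units; within the scatter), so these two saturated chains cannot be told apart from an unsubstituted phenyl on these numbers. Nothing else available offers an explanation for why these swaps leave the numbers so close together.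

The compounds shown leave open whether another group on the same aromatic carbon, such as methoxy, an amine or a carboxylic acid, would move the number beyond the scatter. They also leave open whether a much longer chain on the oxygen next to the carbonyl group would do so.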